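The compounds below may be only part of what the source reports. "The series", "measured", "known", "first", "only" and "open" are said of these compounds alone.

Measured in a functional assay on HEL cells (Homo sapiens); on this read-out higher numbers stand for lower toxicity in this test and lower numbers for higher toxicity in this test:
- compound 1 `CCCCCCc1cc2cn(C3CCC(CO)O3)c(=O)nc2o1`: > 143000 nM
- compound 2 `CCCCCCCCCCCc1cc2cn(C3CCC(CO)O3)c(=O)nc2o1`: > 200000 nM

Compound 1 stands only at a limit, > 143000 nM. Compound 2 is likewise known only as a limit, > 200000 nM.

Compound 3 `CCCCCCCCCCCCCCc1cc2cn(C3CCC(CO)O3)c(=O)nc2o1` differs from compound 1 by octyl in place of hydrogen on a saturated chain carbon, six bonds along the chain from an aromatic carbon. Within the data shown here, the one measured step on this chain, a step that the two limits leave unreadable from compound 1 to compound 2, gives no readable size, so it offers no trend to extend. No change beyond the scatter is therefore expected in this assay. The expected step is a step that the limit leaves unreadable from compound 1 to compound 3. For compound 3 the estimate is 160000 nM, with an expected range from 60000 nM to 280000 nM.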

Compound 3, half-maximal cytotoxic concentration: > 200000 nM
Compound 3: only a limit was reported (the forecaster's own chance of this, stated with the estimate: 70%); middle value at least 1.2-fold (0.09 log units) away from the limit.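

Compound 3 is again known only as a limit, > 200000 nM, so its steps from compound 1 and from compound 2 cannot be read. The compounds shown leave open whether any of these chains has a numerical cytotoxic concentration in this assay.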